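This account rests on a few compounds, and the source may have more. Where it says the series, first, only, none or still open, it means among the compounds named here.

Of the compounds shown here, three of a common core have been measured in a functional assay on MCF7 cells (Homo sapiens) for inhibition; on this read-out lower numbers stand for stronger inhibition and higher numbers for weaker inhibition. Within the data shown here, compound 1 `N#CC1CN1C(=O)Nc1ccc([N+](=O)[O-])cc1` gives 3000 nM, and compound 3 `N#CC1CN1C(=O)Nc1ccccc1` gives 2900 nM; the single step between them, a 1.0-fold lower number from compound 1 to compound 3 (0.01 log units; within the scatter), shows that hydrogen in place of nitro on the aromatic carbon leaves the number where it was. Compound 2 `CNC(=O)N1CC1C#N`, in which the aromatic part is replaced by methylamino, gives 27000 nM; this is the highest of the three numbers, and its gap to compound 1 and to compound 3 lies beyond the scatter in both cases, so compound 2 stands apart as the weakest inhibitor of the set.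

Compound 4 `CCNC(=O)N1CC1C#N` is not yet measured. It differs from compound 2 by methyl in place of hydrogen on a saturated chain carbon bound to an amide-type nitrogen, which, read one bond further out, is methyl to ethyl, or methylamino to ethylamino. Among the measured compounds shown here, none of the measured steps concerns a change of this kind: the only measured step, from compound 1 to compound 3, alters the aromatic substituent, not the chain on the amide-type nitrogen. There is therefore no measured basis for a direction, and a step within the scatter is the most that can be expected. Compound 4 is estimated at 22000 nM, with a range from 7000 nM to 60000 nM. The expected step from compound 2 is a 1.2-fold lower number from compound 2 to compound 4 (0.09 log units; within the scatter).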

Compound 4, half-maximal inhibitory concentration: 29000 nM
Estimate against measurement, compound 4: 1.3-fold (0.12 log units) below; low and high end bracket the measured number.
By their numbers in this assay, from the lowest: compounds 3 and 1 (each within the scatter of the next); then compounds 2 and 4 (each within the scatter of the next).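

In this assay, among these compounds, the step of a 1.1-fold higher number from compound 2 to compound 4 (0.03 log units; within the scatter) gives the first reading of a change on the saturated chain carbon bound to an amide-type nitrogen, and methyl in place of hydrogen there leaves the number where it was. Among the compounds shown here, the only earlier step concerned the aromatic substituent, so this result adds that going from methylamino to ethylamino also makes no difference beyond the scatter. Extending the chain this far does not bring the number toward the low range of the aromatic compounds: compound 4 gives 29000 nM, whereas compound 3 gives 2900 nM. No available evidence bears on why this change leaves the number in place.

The compounds shown leave open whether a longer chain such as butyl, or a chain ending in an amine or a carboxylic acid, would move the number away from that of compound 2. They also leave open whether benzyl, which places a phenyl ring on a chain at this position, would give a number nearer to that of compound 2 or to that of compound 3.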